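Furanyl for ethylphenyl on a pyrazole sulfonate core

The compounds below may be only part of what the source reports. "The series", "measured", "known", "first", "only" and "open" are said of these compounds alone.

Of the compounds shown here, two have been measured so far in a functional assay on the whole organism for inhibition, with Mus musculus as the target, with stated times of 3 days and 30 min, at a dose of 30 mg/kg by the oral route; a higher number here means more inhibition at the dose given (going by the name of the read-out), a lower number less inhibition. Compound 1, `Cc1ccc(-c2cc(C)n(S(=O)(=O)Oc3ccc(I)cc3)n2)cc1`, gives 27% in this assay. Compound 2, `CCc1ccc(-c2cc(C)n(S(=O)(=O)Oc3ccccc3)n2)cc1`, gives 21.1% in this assay, the lowest of the two numbers, though its nearest neighbour, compound 1, sits only a few points away and within the scatter, so no order between them can be read. The unmeasured compound 3, `Cc1cc(-c2ccco2)nn1S(=O)(=O)Oc1ccccc1`, differs from compound 2 in one place: furan-2-yl in place of 4-ethylphenyl on an aromatic carbon. No step between measured compounds is known, so nothing among the numbers shown speaks for or against a change here. The expectation is therefore that the step from compound 2 to compound 3 in this assay, a number 3.1 percentage points lower from compound 2 to compound 3 (within the scatter), stays within the scatter, with a slight lean downward. Compound 3 is accordingly estimated at 18% in this assay, within a range from 4% to 34%.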

Compound 3, a percentage reported as inhibition, in the whole organism at one dose (the size of the read-out at that dose, not a potency): 12.5%
The estimate for compound 3 lay 5.5 percentage points above the measured number; the range from low to high includes it.
By their numbers in this assay, from the lowest: compounds 3, 2 and 1 (each within the scatter of the next, the first and the last beyond it).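

Within the data shown here, the step gives the first reading at this position: in this assay, furan-2-yl in place of 4-ethylphenyl on this aromatic carbon gives a number 8.6 percentage points lower from compound 2 to compound 3 (within the scatter). A six-membered aromatic ring of carbon only can thus give way to a five-membered aromatic ring with a hetero atom, with the ethyl group gone as well, without the two numbers separating beyond the scatter. Nothing available accounts for the size of this step.

From the compounds shown here alone, since this one step changes ring size, the hetero atom and the ethyl group all at once, the share of each remains open. Also open, going by these compounds, is whether an unsubstituted phenyl, a 4-methoxyphenyl or a morpholine on this carbon would give a number beyond the scatter of compound 2.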